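The source may hold more compounds than are shown below. What is called first, only, known or untested is meant among the compounds shown, and "the series" means these compounds.

The account begins with compound 1 `COc1cc(/C=C/C(=O)c2cccc(-n3cc(-c4ccc(Cl)cc4)[nH]c3=O)c2)cc(OC)c1OC`, which in a functional assay on MDA-MB-435 cells (Homo sapiens) for inhibition (on this read-out lower numbers stand for stronger inhibition of growth and higher numbers for weaker inhibition of growth), gives 3630 nM. Two related compounds were measured alongside it: compound 2 `O=C(/C=C/c1cccc(O)c1)c1cccc(-n2cc(-c3ccccc3)[nH]c2=O)c1` gives 3120 nM, and compound 3 `O=C(/C=C/c1cccc(O)c1)c1cccc(-n2cc(-c3ccc(Cl)cc3)[nH]c2=O)c1` gives 2060 nM; the gaps between all three numbers lie within the scatter, so compound 1 stands among them rather than apart. The step to compound 4 `COc1cc(/C=C/C(=O)c2cccc(-n3cc(-c4ccccc4)[nH]c3=O)c2)cc(OC)c1OC` is hydrogen in place of chloro on an aromatic carbon. Within the data shown here, one measured step bears on it, in the reverse direction: a 1.5-fold lower number from compound 2 to compound 3 (0.18 log units; within the scatter). Turning that change around, one expects a similarly small shift toward a higher number, not beyond the scatter. Compound 4 is therefore expected to give 4500 nM, with a likely range from 2200 nM to 9000 nM. The expected step is a 1.2-fold higher number from compound 1 to compound 4 (0.09 log units; within the scatter).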

Compound 4, concentration for 50% growth inhibition: 1200 nM
The estimate for compound 4 lay 3.8-fold (0.57 log units) above the measured number, and the stated range ends above it.
By their numbers in this assay, from the lowest: compounds 4, 3, 2 and 1 (each within the scatter of the next, the first and the last beyond it).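

On the core of compound 1, the change from 4-chlorophenyl to phenyl gives a 3.0-fold lower number from compound 1 to compound 4 (0.48 log units; beyond the scatter), so this position can matter beyond the scatter, which the earlier pair of compounds did not show. The same change does not read alike on the two cores: the same change on two cores in this assay, a 1.5-fold lower number (0.18 log units; within the scatter) from compound 2 to compound 3 and a 3.0-fold higher number (0.48 log units; beyond the scatter) from compound 4 to compound 1, 4.6-fold (0.66 log units) apart, beyond the scatter of two such steps

Which difference between the two cores goes with this gap remains open. With only chloro and hydrogen shown at this position, it is also open how a fluoro, a methoxy or an amine would read on either core.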